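The compounds below may be only part of what the source reports. "The series", "measured", "known", "first", "only" and "open" are said of these compounds alone.

Among the compounds with values here, in an ADME assay on L02 cells (Homo sapiens) for cytotoxicity, read by MTT assay, with a stated time of 72 h (on this read-out lower numbers stand for stronger inhibition and higher numbers for weaker inhibition), compound 1 (`COc1cc(/C=C2\CN(C)C/C(=C\c3cc(OC)c(OC)c(OC)c3)C2=O)cc(OC)c1OC`) gives 26400 nM and so holds the higher of the two numbers so far, while compound 2 (`CCN1C/C(=C\c2ccc(OC)c(OC)c2)C(=O)/C(=C/c2ccc(OC)c(OC)c2)C1`) gives 9800 nM as a lower number, a gap beyond the usual scatter. Compound 3 (`CCC(=O)N1C/C(=C\c2cc(OC)c(OC)c(OC)c2)C(=O)/C(=C/c2cc(OC)c(OC)c(OC)c2)C1`) is still unmeasured. Compared with compound 1 it carries propanoyl in place of methyl on an amine nitrogen in a ring. Within the data shown here, no measured pair shows this change alone, so the expectation in this assay is only a modest fall, just beyond the scatter, and the expected step (a 2.6-fold lower number from compound 1 to compound 3 (0.42 log units; beyond the scatter)) remains uncertain. The estimate for compound 3 is 10000 nM with 3000 nM to 30000 nM as its expected range.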

Compound 3, half-maximal inhibitory concentration: 4200 nM
The estimate for compound 3 lay 2.4-fold (0.38 log units) above the measured number; low and high end bracket the measured number.
By their numbers in this assay, from the lowest: compound 3; then compound 2; then compound 1.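

In this assay, the change from methyl to propanoyl on the amine nitrogen in the ring gives a clear shift (a 6.3-fold lower number from compound 1 to compound 3 (0.80 log units; beyond the scatter)). Within the data shown here, this is the first single-place comparison here, and it shows that the group on this nitrogen can by itself move the number beyond the usual scatter. Nothing measured here explains the step.

As far as these compounds go, whether a plain propyl group or a longer acyl chain such as hexanoyl on this nitrogen would give a similar number remains open. The part played by the carbonyl and the part played by chain length therefore cannot yet be told apart.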